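This account rests on a few compounds, and the source may have more. Where it says the series, first, only, none or still open, it means among the compounds named here.

Of the compounds shown here, three sharing one core have so far been measured in an ADME assay on NHDF cells (Homo sapiens) for cytotoxicity, read by MTT assay, with a stated time of 72 h (a lower number here means a stronger inhibitor, a higher number a weaker inhibitor), and their numbers sit close together. Compound 1 `COc1cccc(/C=C2\CCC/C(=C\c3cccc(Cl)c3)C2=O)c1OC` gives 21400 nM here. Compound 2 `COc1cccc(/C=C2\CCC/C(=C\c3cccc(O)c3)C2=O)c1OC` gives 19300 nM in the same test. Compound 3 `COc1ccc(/C=C2\CCC/C(=C\c3cccc(Cl)c3)C2=O)cc1OC` gives 11900 nM and thus stands within the scatter of both others, so no order can be drawn among the three.

The next compound, compound 4 `COc1ccc(/C=C2\CCC/C(=C\c3ccccc3Br)C2=O)cc1OC`, differs from compound 3 by one group: 2-bromophenyl in place of 3-chlorophenyl on a double-bonded chain carbon bound to a double-bonded ring carbon with 2-bromophenyl in place of 3-chlorophenyl on a double-bonded chain carbon bound to a double-bonded ring carbon.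

Going by the values given here, only one measured step bears on this change. It is a 1.1-fold lower number from compound 1 to compound 2 (0.04 log units; within the scatter) for hydroxy in place of chloro on an aromatic carbon, and it stays within the scatter. Among the compounds with values here, that step removes the chloro group that compound 3 also carries, but no measured compound has a 2-bromophenyl group, so the guidance is thin. On that basis no shift beyond the scatter is expected in this assay in either direction. The expected change is a 1.1-fold higher number from compound 3 to compound 4 (0.04 log units; within the scatter) and no more than that. For compound 4 the estimated value is 13000 nM with an expected range from 6000 nM to 28000 nM in this test.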

Compound 4, half-maximal inhibitory concentration: 21800 nM
Compound 4: the middle estimate sits 1.7-fold (0.22 log units) below what was measured, within the range that was stated.
By their numbers in this assay, from the lowest: compounds 3, 2, 1 and 4 (each within the scatter of the next).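

In this assay, the exchange of 3-chlorophenyl for 2-bromophenyl on a double-bonded chain carbon bound to a double-bonded ring carbon gives a 1.8-fold higher number from compound 3 to compound 4 (0.26 log units; within the scatter), so this position tolerates a change of the whole aryl group without a shift beyond the scatter. The earlier compounds shown here showed only that hydroxy and chloro on an aromatic carbon could be exchanged within the scatter, whereas this step alters both the halogen and its place on the phenyl ring at once, and the two contributions cannot be told apart from this single pair. None of the data at hand accounts for the result, and it supports only the statement that the two compounds cannot be distinguished in this test.

The compounds shown leave open whether 2-chlorophenyl or 3-bromophenyl would behave as these two do, which would separate the identity of the halogen from its place on the ring. They also leave open whether an amine, a carboxylic acid or a longer chain on that phenyl ring would move the number beyond the scatter at all.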